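This account rests on a few compounds, and the source may have more. Where it says the series, first, only, none or still open, it means among the compounds named here.

Compounds measured in a functional assay on Bel-7402 cells (Homo sapiens) for antiproliferative activity, read by MTT assay, with a stated time of 72 h; on this read-out higher numbers stand for weaker inhibition and lower numbers for stronger inhibition:
compound 1 `C=C1C(=O)O[C@H]2[C@H]1CC/C(COC(=O)CCC(=O)OCn1cc(F)c(=O)[nH]c1=O)=C\CC[C@@]1(C)O[C@@H]21`: > 20000 nM
compound 2 `C=C1C(=O)O[C@H]2[C@H]1CC/C(COC(=O)Cn1cc(F)c(=O)n(Cc3ccc(Cl)cc3)c1=O)=C\CC[C@@]1(C)O[C@@H]21`: 2560 nM

In this assay compound 1 returns only a limit, > 20000 nM, and that number is the edge of the assay rather than a measured inhibitory concentration (the limit of > 20000 nM in this assay, at which 1 of the 2 values shown sits). Compound 2 thus supplies the only true number shown, 2560 nM, and there is no second measured value against which to rank it. Compound 3 `C=C1C(=O)O[C@H]2[C@H]1CC/C(COC(=O)Cn1cc(F)c(=O)n(Cc3cc(F)ccc3F)c1=O)=C\CC[C@@]1(C)O[C@@H]21` has not yet been measured. It differs from compound 2 in one place: 2,5-difluorophenyl in place of 4-chlorophenyl on a saturated chain carbon bound to an aromatic nitrogen. For the measured compounds named here, no pair of measured compounds shows this kind of change, so its consequence for the half-maximal inhibitory concentration cannot be read from the data. In this assay the step from compound 2 to compound 3 is expected to be small, a 1.2-fold higher number from compound 2 to compound 3 (0.07 log units; within the scatter), no larger than the usual scatter of repeated measurements. Compound 3 is therefore expected to give about 3000 nM, most likely between 1200 nM and 8000 nM.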

Compound 3, half-maximal inhibitory concentration: 3060 nM
The estimate for compound 3 lay 1.0-fold (0.01 log units) below the measured number, within the range that was stated.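

In this assay, the exchange of 4-chlorophenyl for 2,5-difluorophenyl on a saturated chain carbon bound to an aromatic nitrogen comes to a 1.2-fold higher number from compound 2 to compound 3 (0.08 log units; within the scatter). This position now has two measured groups, and 4-chlorobenzyl and 2,5-difluorobenzyl cannot be told apart on this read-out, although one carries a chlorine and the other two fluorines. No measurement shown bears on a cause for this result.

On these data alone, both groups measured here are halogen-bearing benzyl groups, so it remains open what an unsubstituted benzyl, a methoxybenzyl, a plain methyl or a chain ending in an amine would do at this position. Compound 1 returns only a limit and differs from compound 2 in more than one place, so it gives no readable step for this position.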